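The source may hold more compounds than are shown below. What is called first, only, known or untested is meant among the compounds shown, and "the series" means these compounds.

Within the data shown here, compound 3 `CN(C)c1ccc(NC(=O)Nc2cccc(CNc3nccnc3Cl)c2)cc1` gives 20200 nM in a functional assay on T-24 cells (Homo sapiens) for antiproliferative activity, read by MTT assay, with a stated time of 48 h (on this read-out lower numbers stand for stronger inhibition and higher numbers for weaker inhibition), and stands highest of the three numbers so far. Compound 1 `O=C(Nc1cccc(CNc2nccnc2Cl)c1)Nc1ccccc1Cl` gives 6680 nM and compound 2 `Cc1ccccc1NC(=O)Nc1cccc(CNc2nccnc2Cl)c1` gives 13600 nM in this assay; the two steps in size are a 3.0-fold higher number from compound 1 to compound 3 (0.48 log units; beyond the scatter) and a 1.5-fold higher number from compound 2 to compound 3 (0.17 log units; within the scatter). Compound 4 `COc1ccccc1NC(=O)Nc1cccc(CNc2nccnc2Cl)c1` carries the change 2-methoxyphenyl in place of 4-(dimethylamino)phenyl on an amide-type nitrogen on the shared core. Both measured steps that introduced the 4-(dimethylamino)phenyl group raised the number, one of them beyond the scatter, while the 2-chlorophenyl and 2-methylphenyl analogues sit lower. The step into compound 4 is therefore expected to run back downward by about a 2.0-fold lower number from compound 3 to compound 4 (0.31 log units; beyond the scatter) toward the number that compound 2 shows at 13600 nM in this assay. Compound 4 is estimated at 10000 nM with a range from 4000 nM to 25000 nM in this assay.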

Compound 4, half-maximal inhibitory concentration: 10400 nM
Estimate against measurement, compound 4: 1.0-fold (0.02 log units) below, within the range that was stated.
By their numbers in this assay, from the lowest: compounds 1, 4, 2 and 3 (each within the scatter of the next, the first and the last beyond it).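

In this assay, 2-methoxyphenyl on the amide-type nitrogen stays within the scatter of all three other aryl groups: a 1.9-fold lower number from compound 3 to compound 4 (0.29 log units; within the scatter), a 1.3-fold lower number from compound 2 to compound 4 (0.12 log units; within the scatter) and a 1.6-fold higher number from compound 1 to compound 4 (0.19 log units; within the scatter). Methoxy in place of methyl or chloro on an aromatic carbon therefore gives no readable change at this position. Compound 4 also cannot be separated from either compound 1 or compound 3, although those two lie beyond the scatter of each other.

From the compounds shown here alone, whether an amine or a carboxylic acid on this aromatic ring would move the number beyond the scatter stays open. Nothing available explains these numbers.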